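The compounds below may be only part of what the source reports. "The series", "measured", "known", "first", "only" and "open" are said of these compounds alone.

Two compounds of the series have been run in a functional assay on SMMC-7721 cells (Homo sapiens) for cytotoxicity, read by MTT assay, with a stated time of 4 days; on this read-out higher numbers stand for weaker inhibition and lower numbers for stronger inhibition. Compound 1 `Cc1c(O)ccc2c1[C@H](Cn1cc(-c3ccc(Cl)cc3)nn1)[C@@]13CC(=O)[C@@](C)(CC[C@@H]21)C3` returns only a limit in this assay, > 20000 nM. Compound 2 `C=C1C[C@]23C[C@@]1(O)CC[C@@H]2c1cccc(C)c1[C@@H]3Cn1cc(-c2ccc(OC)cc2)nn1` likewise returns only a limit in this assay, > 20000 nM. Among the measured compounds shown here, neither gives a number, and both sit at the limit of > 20000 nM in this assay, at which 2 of the 2 values shown sit, so nothing separates them and no measured step is available. For the measured compounds named here, compound 2 therefore stands at the limit, not at a number, and the series so far holds no active reference point. The next member is compound 3 `C=C1C[C@]23C[C@@]1(O)CC[C@@H]2c1cccc(C)c1[C@@H]3Cn1cc(-c2ccccn2)nn1`, which differs from compound 2 by pyridin-2-yl in place of 4-methoxyphenyl on an aromatic carbon. Going by the values given here, with no measured step to draw on and both known values at the limit, the expected step from a step that the limit leaves unreadable from compound 2 to compound 3 is none beyond the scatter, a limit being again the most likely outcome. Compound 3 is accordingly estimated at 25000 nM, within a range from 8000 nM to 80000 nM, and a number rather than a limit would be the surprise.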

Compound 3, half-maximal inhibitory concentration: > 20000 nM
Compound 3: a limit, no number; the forecaster's own chance of this, stated with the estimate: 80%; the middle value lies beyond the limit too.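

No step from compound 2 to compound 3 can be read in this assay: the limit of > 20000 nM in this assay, at which 3 of the 3 values shown sit.

Compound 1, compound 2 and compound 3 leave open whether any member of the series gives a number in this assay, and how pyridin-2-yl and 4-methoxyphenyl compare there.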